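This account rests on a few compounds, and the source may have more. Where it says the series, first, only, none or still open, it means among the compounds named here.

Measured so far in a functional assay on HL-60 cells (Homo sapiens) for cytotoxicity, read by MTT assay, with a stated time of 4 days; a higher number here means a weaker inhibitor, a lower number a stronger inhibitor:
compound 1 `Cc1c(O)ccc2c1[C@H](Cn1cc(-c3ccccc3)nn1)[C@@]13CC(=O)[C@@](C)(CC[C@@H]21)C3` — in this assay compound 1 gives > 20000 nM, a limit of the assay.
compound 2 `C=C1C(=O)[C@]23C[C@@]1(O)CC[C@H]2c1ccc(OS(=O)(=O)c2ccc(C)cc2)c(C)c1[C@@H]3Cn1cc(-c2ccc(Cl)cc2)nn1` — in this assay compound 2 gives 1260 nM.
compound 3 `Cc1c(O)ccc2c1[C@H](Cn1cc(-c3ccc(F)cc3)nn1)[C@@]13CC(=O)[C@@](C)(CC[C@@H]21)C3` — in this assay compound 3 gives > 20000 nM, likewise a limit.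

Compound 3 thus stands only at a limit, and no number separates it from compound 1. For the measured compounds named here, compound 2 carries a different core and holds the only numerical value shown. Compound 4 `Cc1c(O)ccc2c1[C@H](Cn1cc(-c3ccc(Cl)cc3)nn1)[C@@]13CC(=O)[C@@](C)(CC[C@@H]21)C3` differs from compound 3 by chloro in place of fluoro on an aromatic carbon. Going by the values given here, the one measured step on a halogen of this ring, a step that the two limits leave unreadable from compound 1 to compound 3, yields no size, since (the limit of > 20000 nM in this assay, at which 2 of the 3 values shown sit). Among the compounds with values here, no step therefore sets a direction or size for this change in this assay. Compound 4 is expected to remain at the limit, with a number no higher from compound 3 to compound 4 (the limit leaves the size open) not resolvable. Compound 4 is estimated at 20000 nM (range 7000 nM to 60000 nM), most likely reported only as a limit.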

Compound 4, half-maximal inhibitory concentration: > 20000 nM
Compound 4: no number, only a limit; the forecaster's own chance of this, stated with the estimate: 70%; the middle value sits exactly at the limit.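

Compound 1, compound 3 and compound 4 all stand at a limit, so no step among them can be read: the limit of > 20000 nM in this assay, at which 3 of the 4 values shown sit.

The compounds shown leave open whether 4-fluorophenyl or 4-chlorophenyl changes potency on this shared core at all.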